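The compounds below may be only part of what the source reports. "The series", "measured", "known", "first", "only" and "open" are said of these compounds alone.

Compound 2 `CC(C)=CCC/C(C)=C/COc1ccc(C2CC2C(=O)NNc2nncc3ccccc23)cc1` is one of two related compounds carrying the same core, the other being compound 1 `CC(C)=CCC/C(C)=C/COc1ccc(C2CC2C(=O)NNC(=O)c2ccncc2)cc1`, which differs in the group attached to the hydrazide. Among the measured compounds shown here, in a functional assay on SK-MEL cells (Homo sapiens) for inhibition, read by MTT assay, with a stated time of 72 h (a higher number here means a weaker inhibitor, a lower number a stronger inhibitor), compound 2 gives 25000 nM, and this is the only number that has been recorded for the pair. In this assay compound 1 has "not determined" (no result reported), so no comparison between the two can be drawn. Compound 3 `CC(C)=CCOc1ccc(C2CC2C(=O)NNc2nncc3ccccc23)cc1` has not yet been tested.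

Compound 3 differs from compound 2 in a single place: hydrogen in place of 3-methylbut-2-en-1-yl on a saturated chain carbon bound to a double-bonded chain carbon. For the measured compounds named here, with no measured step to lean on, the change is expected to leave the weak inhibition seen for compound 2 roughly where it is, with a step from compound 2 to compound 3 in this assay of a 1.2-fold higher number from compound 2 to compound 3 (0.08 log units; within the scatter) that is not expected to exceed the scatter by much. Compound 3 is therefore estimated at 30000 nM, within a range from 10000 nM to 100000 nM.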

Compound 3, half-maximal inhibitory concentration: 67000 nM
The estimate for compound 3 lay 2.2-fold (0.35 log units) below the measured number; the measured number falls inside the stated range.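

Cutting the (3,7-dimethylocta-2,6-dien-1-yl)oxy group back to (3-methylbut-2-en-1-yl)oxy gives the first measured step at this position: in this assay there is a 2.7-fold higher number from compound 2 to compound 3 (0.43 log units; beyond the scatter), a modest step. The loss of the 3-methylbut-2-en-1-yl group on the saturated chain carbon therefore goes with weaker inhibition in this pair, so the length of this chain does bear on the read-out, though only slightly in a compound that was already a weak inhibitor. Nothing at hand accounts for the step, which stands as an observation on one pair.

From the compounds shown here alone, whether a longer chain, a saturated chain of the same length or a chain ending in an amine would move the number further remains open. Also open, going by these compounds, is whether the same shortening would act alike with the hydrazide group of compound 1.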